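A 4-cyanophenyl in place of 3-bromo-4-fluorophenyl

A few compounds are considered here, and "the series" means these few. Any claim that something is new, unique, unknown or untested is made for them only; others in the source may bear on it.

Compound 1 `O=C(Nc1ccccc1)C1CCN(C/C=C/c2ccccc2)CC1`: 57900 nM
Compound 2 `COc1cccc(NC(=O)C2CCN(C/C=C/c3ccccc3)CC2)c1`: 37200 nM
Compound 3 `O=C(Nc1ccc(F)c(Br)c1)C1CCN(C/C=C/c2ccccc2)CC1`: 9270 nM

In a functional assay on MGC-803 cells (Homo sapiens) for inhibition, read by MTT assay, with a stated time of 72 h (on this read-out lower numbers stand for stronger inhibition and higher numbers for weaker inhibition), compound 3 has the lowest number of the three, at 9270 nM. Compound 4 `N#Cc1ccc(NC(=O)C2CCN(C/C=C/c3ccccc3)CC2)cc1` is still unmeasured. It carries 4-cyanophenyl in place of 3-bromo-4-fluorophenyl on an amide-type nitrogen.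

For the measured compounds named here, three measured steps bear on this change. The two that end at the 3-bromo-4-fluorophenyl group are both modest: a 6.2-fold lower number from compound 1 to compound 3 (0.80 log units; beyond the scatter) and a 4.0-fold lower number from compound 2 to compound 3 (0.60 log units; beyond the scatter). The methoxy step, a 1.6-fold lower number from compound 1 to compound 2 (0.19 log units; within the scatter), shows that not every substituent on this ring moves the number beyond the scatter. Going by the values given here, no measured compound carries a nitrile, so the data cannot show whether compound 4 keeps the lower number of compound 3. A modest step back upward in this assay is therefore expected, landing within the span of the measured compounds. The estimated move is a 2.4-fold higher number from compound 3 to compound 4 (0.38 log units; beyond the scatter). For compound 4 the expected value is 22000 nM, with an estimated range of 7000 nM to 60000 nM.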

Compound 4, half-maximal inhibitory concentration: 28200 nM
Compound 4: middle estimate off by 1.3-fold (0.11 log units), on the low side, and the stated range covers the measured number.
By their numbers in this assay, from the lowest: compound 3; then compounds 4, 2 and 1 (each within the scatter of the next, the first and the last beyond it).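

In this assay, the change on the amide-type nitrogen gives back part of the gain seen with 3-bromo-4-fluorophenyl, with a 3.0-fold higher number from compound 3 to compound 4 (0.48 log units; beyond the scatter). The nitrile still counts against the bare phenyl, with a 2.1-fold lower number from compound 1 to compound 4 (0.31 log units; beyond the scatter), so a single substituent on this ring can move the number beyond the scatter, which the methoxy step had not shown. Yet 4-cyanophenyl cannot be told apart from 3-methoxyphenyl, with a 1.3-fold lower number from compound 2 to compound 4 (0.12 log units; within the scatter), so only the 3-bromo-4-fluorophenyl group stands clear of both other substituted compounds.

Nothing available here accounts for these differences. Going by these compounds, it remains open whether bromine alone or fluorine alone would match compound 3, and how an amine or a carboxylic acid on this ring would read.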